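Shortening the alkyl chain on a shared pyrrolidine-type core

The source may hold more compounds than are shown below. What is called first, only, known or untested is meant among the compounds shown, and "the series" means these compounds.

Measured so far:
compound 1, `CCCCCCCCC[C@]1(CO)NC[C@@H](O)[C@@H]1O` — 0%
compound 2, `Cc1ccc([C@@]2(CO)NC[C@H](O)[C@H]2O)cc1` — 3.3%
compound 3, `COc1ccc([C@]2(CO)NC[C@@H](O)[C@@H]2O)cc1OC` — 0%

In an assay on isolated protein for inhibition of tissue alpha-L-fucosidase (Bos taurus), tested at 1000 uM (on this read-out higher numbers stand for more inhibition at the one concentration tested (going by the name of the read-out) and lower numbers for less inhibition), compound 1 gives 0%. Compound 3 gives 0% in this assay, the same figure at the digits reported, and compound 2 gives 3.3% in this assay, a figure that lies within the scatter of both. None of the three substituents on the shared core, whether the long chain or either aryl group, yields an inhibition that can be told apart from zero at the one concentration tested.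

Compound 4, `CCCC[C@]1(CO)NC[C@@H](O)[C@@H]1O`, has not yet been measured. It differs from compound 1 in one place: hydrogen in place of pentyl on a saturated chain carbon, four bonds along the chain from a saturated ring carbon. Since compound 1 with the long chain and compounds 2 and 3 with aryl groups all sit at the same level, there is no reason from these three numbers to expect the shorter chain to behave differently. The step is expected to be a number 1 percentage points higher from compound 1 to compound 4 (within the scatter), none beyond the scatter. Compound 4 is expected to give about 1% in this assay, between -5% and 10%.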

Compound 4, a percentage reported as inhibition, at one concentration (the size of the read-out at that concentration, not a potency): 20.8%
The estimate for compound 4 lay 19.8 percentage points below the measured number, outside the stated range (above it).
By their numbers in this assay, from the lowest: compounds 1, 3 and 2 (each within the scatter of the next); then compound 4.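

In this assay, within the data shown here, the change from compound 1 to compound 4 is the first on the shared core to give a reading that stands clear of the scatter: replacing pentyl with hydrogen at this place on the chain gives a number 20.8 percentage points higher from compound 1 to compound 4 (beyond the scatter). This shows that the chain position is not indifferent to what it carries, which the three earlier compounds, all level within the scatter, could not show. The step remains modest, however, and it rests on one concentration, and nothing available explains why the shorter chain reads differently.

With only two chain lengths shown, it remains open whether an ethyl chain would raise the inhibition further or lose it. As far as these compounds go, it is also open how a chain of the same length as in compound 4 would read if it ended in an amine or a carboxylic acid.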